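Hydroxyl stereocentre inversion on the compound 1 core

The source may report more compounds than this note shows. Statements on the series, on what has been measured and on what is new or still open speak of the compounds shown alone.

Compound 1 `C[C@@H](CC(=O)O)CC(=O)c1c([C@@H](O)CCCCCc2ccccc2)n(C)c2ccc(Cl)cc12` stands second highest of the three numbers in a functional assay for antagonist activity at Oxoeicosanoid receptor 1 (Homo sapiens), read by fluorescence and calcium flux, with stated times of 2 min and 1 min; on this read-out higher numbers stand for weaker inhibition and lower numbers for stronger inhibition: compound 1 gives 120 nM. Its nearest neighbour is compound 2 `CC(CC(=O)O)CC(=O)n1c(CCCc2ccccc2)cc2ccc(Cl)cc21`, which in this assay gives 210 nM, a gap that lies within the scatter, so no order between the two is claimed. Furthest away is compound 3 `CC(CC(=O)O)CC(=O)n1c(CCCCCCc2ccccc2)cc2ccc(Cl)cc21`, which in this assay gives 12 nM. Going by the values given here, the single measured step in the set, an 18-fold lower number from compound 2 to compound 3 (1.24 log units; beyond the scatter), concerns a chain on a different core and does not involve compound 1.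

Compound 4 `C[C@@H](CC(=O)O)CC(=O)c1c([C@H](O)CCCCCc2ccccc2)n(C)c2ccc(Cl)cc12` keeps every atom and bond of compound 1; (the two compounds have the same atoms and bonds and differ only in configuration as drawn: 1 of 2 stereo elements differ; a stereocentre at a saturated chain carbon is drawn S in compound 1 and R in compound 4). Among the compounds with values here, no measured pair in this set differs by configuration alone, so nothing here shows how an inversion at that carbon moves the number, and the chain step gives no guide to it. The expectation is therefore anchored on compound 1 with wide uncertainty in either direction; the change is expected to give a 2.1-fold higher number from compound 1 to compound 4 (0.32 log units; beyond the scatter), with a weakening more likely than a strengthening since the measured epimer is the one drawn S. Compound 4 is estimated at 250 nM, between 50 nM and 1500 nM.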

Compound 4, half-maximal inhibitory concentration: 750 nM
Compound 4: the middle estimate sits 3.0-fold (0.48 log units) below what was measured, and the stated range covers the measured number.
By their numbers in this assay, from the lowest: compound 3; then compounds 1 and 2 (each within the scatter of the next); then compound 4.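

Inverting the stereocentre at a saturated chain carbon gives, in this assay, a 6.3-fold higher number from compound 1 to compound 4 (0.80 log units; beyond the scatter), so the number at this position responds to configuration alone, with the S form as drawn giving the lower number of the pair. The whole of that step can be assigned to the inversion, because nothing else in the structure varies: the fact that compounds 1 and 4 differ only in the configuration as drawn. Going by these compounds alone, the earlier compounds offered only a chain step on a different core, an 18-fold lower number from compound 2 to compound 3 (1.24 log units; beyond the scatter), so this pair is the only reading in the set of how configuration acts on the core of compound 1, and it shows that a change with no atom or bond entering or leaving can move the number beyond the scatter.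

As far as these compounds go, it remains open how much of the number depends on the hydroxyl itself, a question that a ketone or a methoxy group in place of the hydroxyl would address. Also open, from the compounds shown here alone, are the contribution of the second stereocentre, drawn alike in compound 1 and compound 4, and whether the gap between the two forms persists with a longer chain.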